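The compounds below may be only part of what the source reports. "The series", "measured", "known", "first", "only" and "open" are said of these compounds alone.

In a functional assay on Hs-578T cells (Homo sapiens) for antiproliferative activity (a higher number here means a weaker inhibitor of growth, a lower number a stronger inhibitor of growth), compound 1 `COCCCCCCCCCCCCCCC/C=C1\CC(CO)(COC(=O)C(C)(C)C)OC1=O` gives 5.45 ug/mL. Compound 2 `COCCCCCCCCCCC/C=C1\CC(CO)(COC(=O)C(C)(C)C)OC1=O` gives 7.34 ug/mL in this assay. Compound 3 `CC(=O)NCCCCCCCCCCCCCCC/C=C1\CC(CO)(COC(=O)C(C)(C)C)OC1=O` reaches only a limit in this assay, > 10 ug/mL. Compound 3 therefore stands at the limit of > 10 ug/mL in this assay, at which 1 of the 3 values shown sits, with no number of its own. The steps that lead to it, an at least 1.8-fold higher number from compound 1 to compound 3 (0.26 log units; that floor lies within the scatter) and an at least 1.3-fold higher number from compound 2 to compound 3 (0.13 log units; that floor lies within the scatter), have floors lying within the scatter, and the step of a 1.3-fold higher number from compound 1 to compound 2 (0.13 log units; within the scatter) is likewise within it. Compound 4 `CC(C)(C)C(=O)OCCCCCCCCCCCCCCC/C=C1\CC(CO)(COC(=O)C(C)(C)C)OC1=O` differs from compound 3 in one place: ((tert-butyl)carbonyl)oxy in place of acetamido on a saturated chain carbon, ten or more bonds along the chain from a double-bonded chain carbon. Among the measured compounds shown here, none of the measured steps exchanges the acetamido for an ester, so their bearing is indirect; all three are small, and one expects compound 4 to land near compound 1 and compound 2, with the expected step being an at least 1.4-fold lower number from compound 3 to compound 4 (0.15 log units; that floor lies within the scatter). Compound 4 is estimated at 7 ug/mL, between 3.5 ug/mL and 14 ug/mL.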

Compound 4, concentration for 50% growth inhibition: 5.24 ug/mL
Estimate against measurement, compound 4: 1.3-fold (0.13 log units) above; the measured number falls inside the stated range.
By their numbers in this assay, from the lowest: compounds 4, 1 and 2 (each within the scatter of the next). At a limit, above all of these: compound 3.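

In this assay, ((tert-butyl)carbonyl)oxy on this saturated chain carbon gives a result indistinguishable from the methoxy compounds, with the steps being a 1.0-fold lower number from compound 1 to compound 4 (0.02 log units; within the scatter) and a 1.4-fold lower number from compound 2 to compound 4 (0.15 log units; within the scatter). Against acetamido, the change reads as an at least 1.9-fold lower number from compound 3 to compound 4 (0.28 log units; that floor lies within the scatter), so it establishes no real separation between the two groups. Compound 3 remains a limit rather than a number: the limit of > 10 ug/mL in this assay, at which 1 of the 4 values shown sits.

Going by these compounds, whether acetamido truly differs from the ester and the methoxy group stays open. So does the outcome with an amine or a carboxylic acid on this carbon, or with a longer chain.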